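This account rests on a few compounds, and the source may have more. Where it says the series, first, only, none or still open, it means among the compounds named here.

Compounds measured in a functional assay for inhibition, with Homo sapiens as the target; on this read-out lower numbers stand for stronger inhibition and higher numbers for weaker inhibition: compound 1 (`CCc1ccc(Nc2nccc(-c3cnccn3)n2)cc1`) gives 1900 nM; compound 2 (`c1ccc(-c2ccnc(Nc3ccc(-n4ccnc4)cc3)n2)nc1`) gives 1400 nM; compound 3 (`CCc1ccc(Nc2nccc(-c3ccncc3)n2)cc1`) gives 7700 nM.

Compound 3 stands highest of the three numbers. Its nearest neighbour is compound 1, the gap being a 4.1-fold higher number from compound 1 to compound 3 (0.61 log units; beyond the scatter), and compound 2 lies further off still. Compound 4 (`c1cc(-c2ccnc(Nc3ccc(-n4ccnc4)cc3)n2)ccn1`) has not yet been measured. Against compound 3 it carries 1H-imidazol-1-yl in place of ethyl on an aromatic carbon. Among the compounds with values here, the single step recorded so far, a 4.1-fold higher number from compound 1 to compound 3 (0.61 log units; beyond the scatter), concerns the other end of the shared core and so does not bear directly on this change. Compounds 1 and 2 differ in two places at once, one of them this same exchange of ethyl for 1H-imidazol-1-yl; since compound 1 gives 1900 nM and compound 2 gives 1400 nM, values within the scatter of each other, that pair gives no sign that the exchange moves the number much. The step from compound 3 to compound 4 is therefore expected to stay within the scatter, with at most a slight lowering, and the estimate for compound 4 in this assay is 5500 nM, in the range 2000 nM to 15000 nM, meaning an expected step of a 1.4-fold lower number from compound 3 to compound 4 (0.15 log units; within the scatter).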

Compound 4, half-maximal inhibitory concentration: 7600 nM
For compound 4 the middle estimate is 1.4-fold (0.14 log units) below the measured one; the range from low to high includes it.
By their numbers in this assay, from the lowest: compounds 2 and 1 (each within the scatter of the next); then compounds 4 and 3 (each within the scatter of the next).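

In this assay the step of a 1.0-fold lower number from compound 3 to compound 4 (0.01 log units; within the scatter) reads the exchange of ethyl for 1H-imidazol-1-yl on its own, on an aromatic carbon para to a large group, whereas compound 1 and compound 2 differ in two places at once. With pyridin-4-yl held constant, the two groups cannot be told apart at this position, even though the entering group brings a five-membered aromatic ring and 2 hydrogen-bond acceptors that ethyl lacks. The step of a 5.4-fold higher number from compound 2 to compound 4 (0.73 log units; beyond the scatter) for pyridin-4-yl in place of pyridin-2-yl lies beyond the scatter, as does the step of a 4.1-fold higher number from compound 1 to compound 3 (0.61 log units; beyond the scatter) for pyridin-4-yl in place of pyrazin-2-yl, so among these four compounds, with none going against it, the number follows that other group, whether ethyl or 1H-imidazol-1-yl is present, and no measurement is available that would explain either finding.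

The compounds shown leave open whether the exchange of ethyl for 1H-imidazol-1-yl reads the same when pyridin-2-yl or pyrazin-2-yl replaces pyridin-4-yl. They also leave open how an amine, a carboxylic acid or a longer chain would behave at this same aromatic carbon.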